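The compounds below may be only part of what the source reports. "The series", "measured", "known", "first", "only" and "open" are said of these compounds alone.

Measured in a functional assay on DLD-1 cells (Homo sapiens) for cytotoxicity, with a stated time of 48 h; on this read-out lower numbers stand for stronger inhibition and higher numbers for weaker inhibition:
Compound 1 `CC(C)COc1ccc2oc(/C=C/[S+](C)[O-])cc(=O)c2c1`: 5000 nM
Compound 2 `C[S+]([O-])/C=C/c1cc(=O)c2ccccc2o1`: 8000 nM
Compound 3 `CCCC(=O)Oc1ccc2oc(/C=C/[S+](C)[O-])cc(=O)c2c1`: 8700 nM

These three compounds cannot be told apart on these numbers. Compound 3 lies within the scatter of both others, as a 1.1-fold higher number from compound 2 to compound 3 (0.04 log units; within the scatter) and a 1.7-fold higher number from compound 1 to compound 3 (0.24 log units; within the scatter) show.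

The next compound is compound 4 `CC(C)CCOc1ccc2oc(/C=C/[S+](C)[O-])cc(=O)c2c1`, which has not yet been measured. Its difference from compound 3 is isopentyl in place of propylcarbonyl on an oxygen on an aromatic ring.

All three measured steps bear on this change. The closest is the step that puts propylcarbonyl in place of isobutyl on that kind of oxygen, a 1.7-fold higher number from compound 1 to compound 3 (0.24 log units; within the scatter). Compound 4 returns to a plain chain without a carbonyl, like the isobutyl of compound 1, so it is expected to resemble compound 1 at 5000 nM. Even replacing isobutoxy with hydrogen gave only a 1.6-fold higher number from compound 1 to compound 2 (0.20 log units; within the scatter). No measured change has gone beyond the scatter, so no larger move is expected here, and three compounds are a thin basis. The expected step is a 1.7-fold lower number from compound 3 to compound 4 (0.24 log units; within the scatter). For compound 4 the estimated value is 5000 nM, with an expected range from 2300 nM to 10000 nM.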

Compound 4, half-maximal inhibitory concentration: 4100 nM
Estimate against measurement, compound 4: 1.2-fold (0.09 log units) above; the measured number falls inside the stated range.
By their numbers in this assay, from the lowest: compounds 4, 1, 2 and 3 (each within the scatter of the next, the first and the last beyond it).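

In this assay, this oxygen shows its first change beyond the scatter, though a modest one: putting isopentyl in place of propylcarbonyl gives a 2.1-fold lower number from compound 3 to compound 4 (0.33 log units; beyond the scatter), and the two groups have 5 heavy atoms each, so the step removes the carbonyl without changing that count. The same group does not separate from its neighbours in the other two comparisons: isopentyloxy in place of hydrogen gives a 2.0-fold lower number from compound 2 to compound 4 (0.29 log units; within the scatter), and isopentyl in place of isobutyl gives a 1.2-fold lower number from compound 1 to compound 4 (0.09 log units; within the scatter), so neither the presence of a chain on the oxygen nor its extension by itself is shown to matter. Nothing available explains why the isopentyl and propylcarbonyl compounds differ.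

The contrast also rests on a single pair, since the comparable step from isobutyl to propylcarbonyl, a 1.7-fold higher number from compound 1 to compound 3 (0.24 log units; within the scatter), stays within the scatter and so goes against any general rule about the carbonyl. The compounds shown leave open how this oxygen would respond to a much longer chain such as octyl, to a benzyl group, or to a chain ending in an amine or a carboxylic acid.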